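This account rests on a few compounds, and the source may have more. Where it says the series, first, only, none or still open, it means among the compounds named here.

Working notes. In an assay on isolated protein for inhibition of Rho-associated protein kinase 2 (Homo sapiens), read by scintillation counting, radiometric assay and 33P incorporation, with a stated time of 40 min, in the presence of a further agent that is not named here (on this read-out higher numbers stand for weaker inhibition and lower numbers for stronger inhibition), compound 1 `Cc1ccc(NC(=O)COc2ccc3c(=O)ccoc3c2)cc1NC(=O)c1ccc(N(C)C)cc1` gives 169 nM. Compound 2 `Cc1cc(NC(=O)COc2ccc3c(=O)ccoc3c2)cc(NC(=O)c2ccc(N(C)C)cc2)c1` is the companion lacking any substituent of that kind on the ring of the shared core bearing the two amide nitrogens. In this assay compound 2 returns only a limit, > 10000 nM, which is the point noted at the limit of > 10000 nM in this assay, at which 1 of the 2 values shown sits. Among the compounds with values here, no quantified step between compound 1 and compound 2 exists; the two values show one compound within the measured range and the other outside it. Compound 3 `Cc1cc(NC(=O)COc2ccc3c(=O)ccoc3c2)cc(NC(=O)c2ccc(N(C)C)cc2)c1C` differs from compound 2 by methyl in place of hydrogen on an aromatic carbon. With compound 2 sitting at a limit, the size of the step from compound 2 to compound 3 in this assay cannot be anchored; a move back toward measurable inhibition is expected, of about an at least 2.0-fold lower number from compound 2 to compound 3 (0.30 log units; that floor lies within the scatter). For compound 3 the estimate in this assay is 5000 nM, within 1000 nM to 20000 nM.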

Compound 3, half-maximal inhibitory concentration: 374 nM
Estimate against measurement, compound 3: 13-fold (1.13 log units) above, and the stated range ends above it.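

In this assay, methyl on this aromatic carbon, ortho to the ((4-(dimethylamino)phenyl)carbonyl)amino group and ortho to a methyl group, brings the arrangement of compound 2 back into the measured range, with an at least 26-fold lower number from compound 2 to compound 3 (1.42 log units; beyond the scatter). That step has only a floor, since the value of compound 2 is a limit and not a number: the limit of > 10000 nM in this assay, at which 1 of the 3 values shown sits. The arrangement of compound 2 is therefore not incompatible with measurable inhibition once this position carries methyl, although a 2.2-fold higher number from compound 1 to compound 3 (0.34 log units; beyond the scatter) shows that compound 3 does not fully reach compound 1.

The compounds shown leave open whether this recovery is specific to methyl or would also occur with an ethyl group, a methoxy group or a chlorine atom on this carbon. They give no basis for assigning a cause to the step.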